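Swapping the triazole tail for a hydroxypiperidine chain

The source may report more compounds than this note shows. Statements on the series, on what has been measured and on what is new or still open speak of the compounds shown alone.

Compound 1 `O=C1c2c[n+]([O-])c3ccccc3c2C(=O)c2c1c1ccccc1n2Cc1cn(C[C@H](O)CO)nn1`: 8880 nM
Compound 2 `CN1CCN(CCCCCCn2c3c(c4ccccc42)C(=O)c2c[n+]([O-])c4ccccc4c2C3=O)CC1`: 5800 nM
Compound 3 `O=C1c2c[n+]([O-])c3ccccc3c2C(=O)c2[nH]c3ccccc3c21`: 890 nM

These three compounds share one core and differ only in what hangs from the aromatic nitrogen. In a toxicity assay on HEK-293T cells (Homo sapiens) for cytotoxicity, read by MTT assay, with a stated time of 72 h (on this read-out lower numbers stand for stronger inhibition and higher numbers for weaker inhibition), compound 1 gives the highest number of the three; compound 2 lies within the scatter of it (a 1.5-fold lower number from compound 1 to compound 2 (0.18 log units; within the scatter)), while compound 3 sits further off (a 10-fold lower number from compound 1 to compound 3 (1.00 log units; beyond the scatter)). Compound 4 `O=C1c2c[n+]([O-])c3ccccc3c2C(=O)c2c1c1ccccc1n2CCCN1CCC(O)CC1` is not yet measured. It differs from compound 1 in one place: 2-(4-hydroxypiperidin-1-yl)ethyl in place of 1-(2,3-dihydroxypropyl)-1H-1,2,3-triazol-4-yl on a saturated chain carbon bound to an aromatic nitrogen. The step to compound 2, which also exchanges the tail on that saturated chain carbon, is the closest guide and stayed within the scatter; the larger step to compound 3 removed the whole substituent, which compound 4 does not do. The expected change is therefore small: a 1.6-fold lower number from compound 1 to compound 4 (0.21 log units; within the scatter). Compound 4 is estimated at 5500 nM, between 1800 nM and 16000 nM.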

Compound 4, half-maximal inhibitory concentration: 170 nM
Estimate against measurement, compound 4: 32-fold (1.51 log units) above, outside the stated range (below it).
By their numbers in this assay, from the lowest: compound 4; then compound 3; then compounds 2 and 1 (each within the scatter of the next).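

In this assay, the tail at this position turns out to matter far more than the earlier tail exchange suggested, since 2-(4-hydroxypiperidin-1-yl)ethyl gives a large drop (a 52-fold lower number from compound 1 to compound 4 (1.72 log units; beyond the scatter)) and also stands well apart from the piperazine tail (a 34-fold lower number from compound 2 to compound 4 (1.53 log units; beyond the scatter)). Unlike the substituent in compound 1, the 3-(4-hydroxypiperidin-1-yl)propyl group gives a lower number than hydrogen on the aromatic nitrogen (a 5.2-fold lower number from compound 3 to compound 4 (0.72 log units; beyond the scatter)). No supporting data explain this difference.

As far as these compounds go, whether the hydroxyl is needed remains open, as an unsubstituted piperidine would test that. A shorter or longer chain carrying the same ring is equally unresolved.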